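One More Chain Carbon on Compound 3

The compounds below may be only part of what the source reports. "The series", "measured", "known", "first", "only" and "open" are said of these compounds alone.

Of the compounds shown here, three have so far been read in a functional assay on HEL cells (Homo sapiens); on this read-out higher numbers stand for lower toxicity in this test and lower numbers for higher toxicity in this test. Compound 1 `CCCCc1cc2cn(COCCO)c(=O)nc2o1` gives only a limit of the assay, > 200000 nM. Compound 2 `CCCCCCCC#Cc1cc2cn(COCCO)c(=O)nc2o1` also gives only a limit, > 50000 nM. Among the compounds with values here, compound 3 `CCCCCCCc1cc2cn(COCCO)c(O)nc-2n1` gives 119000 nM, the only true number among the three.

Compound 4 `CCCCCCCCc1cc2cn(COCCO)c(O)nc-2n1` departs from compound 3 in one place: methyl in place of hydrogen on a saturated chain carbon, seven bonds along the chain from an aromatic carbon. This is methyl in place of hydrogen on a saturated chain carbon, seven bonds along the chain from an aromatic carbon. Within the data shown here, no pair of measured compounds isolates a change of this kind, so the expectation has no direct precedent to lean on. The step in this assay is expected to be small and to remain within the usual scatter, with only a mild lean toward lower numbers, meaning somewhat higher toxicity. Among the measured compounds shown here, the anchor for this expectation is compound 3 at 119000 nM, the one true number available. The expected change is a 1.2-fold lower number from compound 3 to compound 4 (0.08 log units; within the scatter). For compound 4 the estimated value is 100000 nM, with an expected range from 45000 nM to 200000 nM.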

Compound 4, half-maximal cytotoxic concentration: 65000 nM
Estimate against measurement, compound 4: 1.5-fold (0.19 log units) above; low and high end bracket the measured number.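

With this pair, this assay gains its first step that isolates a single change, methyl in place of hydrogen on a saturated chain carbon, seven bonds along the chain from an aromatic carbon: a 1.8-fold lower number from compound 3 to compound 4 (0.26 log units; within the scatter). The earlier compounds shown here could not show this, as compound 1 and compound 2 each give only a limit of the assay and neither forms a one-place pair with compound 3, whereas here two true numbers can be read side by side and, at this position, this change leaves them inside the usual scatter of the read-out. The values shown offer no explanation of this step, and the information available on the other compounds does not bear on it.

What the compounds shown leave open is whether a longer chain at this place would move the number beyond the scatter, or whether the small step seen here would simply repeat. From the compounds shown here alone, it also remains open how a hydroxyl or an amine at the far end of the chain would read, and whether the same added methyl would give a similar step on the core of compound 1.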